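The source may hold more compounds than are shown below. What is called first, only, known or untested is meant among the compounds shown, and "the series" means these compounds.

Measured so far:
- compound 1 `CC1(C)[C@H]2CC[C@]1(C)N(Cc1cn(-c3ccc(O)cc3)nn1)C(=O)C2` gives 410 nM in a functional assay on OVCAR-3 cells (Homo sapiens) for inhibition, read by MTT assay, with a stated time of 24 h; a lower number here means a stronger inhibitor, a higher number a weaker inhibitor
- compound 2 `Cc1ccc(-n2cc(CN3C(=O)C[C@@H]4CC[C@@]3(C)C4(C)C)nn2)cc1` gives 40 nM in this assay

Compound 2 stands lowest of the two at 40 nM and is the stronger inhibitor of the pair. Next comes compound 3 `COc1cccc(-n2cc(CN3C(=O)C[C@@H]4CC[C@@]3(C)C4(C)C)nn2)c1` with 3-methoxyphenyl in place of 4-methylphenyl on an aromatic nitrogen and the shared core unchanged. For the measured compounds named here, one measured step bears on this group: a 10-fold lower number from compound 1 to compound 2 (1.01 log units; beyond the scatter) with methyl in place of hydroxy on an aromatic carbon. That step is large and beyond the scatter, so changes on this aromatic ring can matter. Going by the values given here, no measured compound carries 3-methoxyphenyl, so the step gives no direct read-across. A moderate move to a higher number is expected in this assay and this is smaller than the measured step. The estimated change is a 2.5-fold higher number from compound 2 to compound 3 (0.40 log units; beyond the scatter) on this limited evidence. The estimate for compound 3 is 100 nM within an expected range of 25 nM to 400 nM in this series.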

Compound 3, half-maximal inhibitory concentration: 280 nM
Compound 3: the middle estimate sits 2.8-fold (0.45 log units) below what was measured; measured number inside the range.
By their numbers in this assay, from the lowest: compound 2; then compounds 3 and 1 (each within the scatter of the next).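

In this assay, the aryl group on the aromatic nitrogen now has a second comparison, a 7.0-fold higher number from compound 2 to compound 3 (0.85 log units; beyond the scatter) with 3-methoxyphenyl in place of 4-methylphenyl. Against 4-hydroxyphenyl, the same group gives a 1.5-fold lower number from compound 1 to compound 3 (0.17 log units; within the scatter), so these two groups are not separated here, and only the 4-methylphenyl of compound 2 stands apart among the three. Nothing on hand accounts for this difference.

The step to compound 3 changes both the group and its number on the phenyl ring, so the compounds shown cannot divide the effect between the two; 3-methylphenyl and 4-methoxyphenyl would each change only one. Also open, on these data alone, is how this position responds to groups such as ethyl, an amine or a carboxylic acid on the phenyl ring.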